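This account rests on a few compounds, and the source may have more. Where it says the series, first, only, none or still open, it means among the compounds named here.

Compound 1, `COc1cc2ncnc(Nc3cccc(F)c3)c2cc1OCCCCC(=O)Nc1ccc(S(N)(=O)=O)cc1`, in a functional assay on NCI-H1975 cells (Homo sapiens) for antiproliferative activity, read by MTT assay, with a stated time of 72 h (on this read-out lower numbers stand for stronger inhibition and higher numbers for weaker inhibition), gives > 40000 nM, which is a limit of the assay and not a number.
Compound 2, `COc1cc2ncnc(Nc3ccc(Cl)cc3)c2cc1OCCCCC(=O)Nc1ccc(S(N)(=O)=O)cc1`, in this assay gives 31800 nM.
Compound 3, `COc1cc2ncnc(Nc3ccc(Br)cc3)c2cc1OCCCCC(=O)Nc1ccc(S(N)(=O)=O)cc1`, in this assay gives 23300 nM.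

Compound 3 holds the lowest of the two numbers shown, with compound 2 nearest at a 1.4-fold lower number from compound 2 to compound 3 (0.14 log units; within the scatter), a gap that lies within the scatter; compound 1 sits at the limit given by the limit of > 40000 nM in this assay, at which 1 of the 3 values shown sits. Compound 4, `COc1cc2ncnc(Nc3cccc(Cl)c3F)c2cc1OCCCCC(=O)Nc1ccc(S(N)(=O)=O)cc1`, differs from compound 3 by 3-chloro-2-fluorophenyl in place of 4-bromophenyl on a nitrogen on an aromatic ring. Among the compounds with values here, the steps that bear on this change are an at least 1.2-fold lower number from compound 1 to compound 2 (0.09 log units; that floor lies within the scatter), an at least 1.7-fold lower number from compound 1 to compound 3 (0.23 log units; that floor lies within the scatter) and a 1.4-fold lower number from compound 2 to compound 3 (0.14 log units; within the scatter), and each of them stays within the scatter, so exchanging one halogenated phenyl for another on this nitrogen has not moved this assay beyond the scatter so far. Compound 4 is therefore expected to give a number close to that of compound 3, with a 1.2-fold higher number from compound 3 to compound 4 (0.08 log units; within the scatter) as the estimated step. For compound 4 the estimate in this assay is 28000 nM, with a range from 12000 nM to 60000 nM, and a real chance that only a limit is reported.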

Compound 4, half-maximal inhibitory concentration: 6930 nM
Estimate against measurement, compound 4: 4.0-fold (0.61 log units) above; the measured number lies below the stated range.
By their numbers in this assay, from the lowest: compound 4; then compounds 3 and 2 (each within the scatter of the next). At a limit, above all of these: compound 1.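

Unlike the steps among compound 1, compound 2 and compound 3, the exchange on this nitrogen on an aromatic ring to 3-chloro-2-fluorophenyl moves this assay beyond the scatter, with a 3.4-fold lower number from compound 3 to compound 4 (0.53 log units; beyond the scatter) and a 4.6-fold lower number from compound 2 to compound 4 (0.66 log units; beyond the scatter). The third step, an at least 5.7-fold lower number from compound 1 to compound 4 (0.76 log units; beyond the scatter), starts from a limit of the assay and not a number, so it is a floor only: the limit of > 40000 nM in this assay, at which 1 of the 4 values shown sits. Among the compounds shown, only the group carrying both fluorine and chlorine gives a step of this size.

As far as these compounds go, what a 3-chlorophenyl or a 2-fluorophenyl group on this nitrogen would give stays open, so the step cannot be assigned to either halogen. Also open, from the compounds shown here alone, is how this assay would read with a 3-ethynylphenyl group on this nitrogen, or with a longer chain to the sulfonamide-bearing amide.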